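Nitro in place of methyl: compound 3 to compound 4

The compounds below may be only part of what the source reports. "The series", "measured", "known", "first", "only" and "open" are said of these compounds alone.

Measured so far in a functional assay on MCF7 cells (Homo sapiens) for antiproliferative activity, read by MTT assay, with a stated time of 48 h; a lower number here means a stronger inhibitor, a higher number a weaker inhibitor:
- compound 1 `O=[N+]([O-])c1cccc(-c2nn(-c3ccccc3)cc2C(Nc2nc3ccccc3s2)c2c(O)ccc3ccccc23)c1`: 43900 nM
- compound 2 `Cc1ccc2nc(NC(c3cn(-c4ccccc4)nc3-c3cccc(Cl)c3)c3c(O)ccc4ccccc34)sc2c1`: 49700 nM
- compound 3 `Cc1ccc(-c2nn(-c3ccccc3)cc2C(Nc2nc3cc(C)c(C)cc3s2)c2c(O)ccc3ccccc23)cc1`: 22400 nM

Compound 3 and compound 1 lie within the usual scatter of each other, while compound 3 reads lower than compound 2 by more than the scatter. Unmeasured compound 4 `Cc1cc2nc(NC(c3cn(-c4ccccc4)nc3-c3ccc([N+](=O)[O-])cc3)c3c(O)ccc4ccccc34)sc2cc1C` replaces 4-methylphenyl with 4-nitrophenyl: nitro in place of methyl on an aromatic carbon. Within the data shown here, no measured pair shows this change alone. Compound 1 also carries a nitro group and gives 43900 nM, so only a small upward step, within the scatter, is expected in this assay. The expected change is a 1.3-fold higher number from compound 3 to compound 4 (0.13 log units; within the scatter). For compound 4 the estimated value is 30000 nM, with an expected range of 13000 nM to 70000 nM.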

Compound 4, half-maximal inhibitory concentration: 41100 nM
Compound 4: the middle estimate sits 1.4-fold (0.14 log units) below what was measured, within the range that was stated.
By their numbers in this assay, from the lowest: compounds 3, 4, 1 and 2 (each within the scatter of the next, the first and the last beyond it).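

In this assay the swap of 4-methylphenyl for 4-nitrophenyl gives a 1.8-fold higher number from compound 3 to compound 4 (0.26 log units; within the scatter) and so the two groups cannot be told apart at this position. Among these compounds, this is the first pair to show this change alone, with the rest of the structure held fixed. Nothing available explains the reading. Going by these compounds, whether an amine or a carboxylic acid at this same position would move the number beyond the scatter stays open. So does whether this step would look the same on a differently substituted core.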